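The source may report more compounds than this note shows. Statements on the series, on what has been measured and on what is new or still open speak of the compounds shown alone.

Measured in a functional assay on MDA-MB-231 cells (Homo sapiens) for antiproliferative activity, read by MTT assay, with a stated time of 72 h; a lower number here means a stronger inhibitor, a higher number a weaker inhibitor:
Compound 1 `CC1=CC[C@H]2[C@H](CC[C@]2(C)O)C(C)(C)[C@@H]1CC[C@H]1[C@]2(C)CC[C@H](OC(=O)c3ccc(C)cc3)C(C)(C)O[C@H]2CC[C@@]1(C)O`: 33400 nM
Compound 2 `CC1=CC[C@H]2[C@H](CC[C@]2(C)O)C(C)(C)[C@@H]1CC[C@H]1[C@]2(C)CC[C@H](OC(=O)NCc3ccccc3)C(C)(C)O[C@H]2CC[C@@]1(C)O`: 40300 nM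
Compound 3 `CC1=CC[C@H]2[C@H](CC[C@]2(C)O)C(C)(C)[C@@H]1CC[C@H]1[C@]2(C)CC[C@H](OC(=O)c3ccc([N+](=O)[O-])cc3)C(C)(C)O[C@H]2CC[C@@]1(C)O`: 8900 nM

Compound 3 has the lowest number of the three, which makes it the strongest inhibitor in this small set. Compound 4 `CC1=CC[C@H]2[C@H](CC[C@]2(C)O)C(C)(C)[C@@H]1CC[C@H]1[C@]2(C)CC[C@H](OC(=O)c3cccc([N+](=O)[O-])c3)C(C)(C)O[C@H]2CC[C@@]1(C)O` differs from it only in where the nitro group sits: 3-nitrophenyl in place of 4-nitrophenyl on a carbonyl carbon, with 3-nitrophenyl in place of 4-nitrophenyl on a carbonyl carbon. The closest measured change is a 3.8-fold lower number from compound 1 to compound 3 (0.57 log units; beyond the scatter), where nitro replaced methyl, and a 4.5-fold lower number from compound 2 to compound 3 (0.66 log units; beyond the scatter) is also modest. Neither step moves a group around the ring, so the data offer no direct guide to this shift. Compound 4 still carries a nitro group, so only a small change is expected. In this assay the expected result is a 1.3-fold higher number from compound 3 to compound 4 (0.13 log units; within the scatter), a slight rise. The estimated value for compound 4 is 12000 nM, with an expected range of 5000 nM to 30000 nM.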

Compound 4, half-maximal inhibitory concentration: 34700 nM
Compound 4: the middle estimate sits 2.9-fold (0.46 log units) below what was measured; measured number above the stated range.
By their numbers in this assay, from the lowest: compound 3; then compounds 1, 4 and 2 (each within the scatter of the next).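

In this assay, moving the nitro group alone gives a 3.9-fold higher number from compound 3 to compound 4 (0.59 log units; beyond the scatter), although the atoms stay the same. The lower number of compound 3 therefore belongs to 4-nitrophenyl, not to just any nitrophenyl group. The 3-nitrophenyl group brings no such benefit, with a 1.0-fold higher number from compound 1 to compound 4 (0.02 log units; within the scatter) and a 1.2-fold lower number from compound 2 to compound 4 (0.06 log units; within the scatter). Nothing measured here explains this difference between the two placements.

Going by these compounds, whether the lower number needs the nitro group itself remains open. A 4-cyanophenyl or 4-aminophenyl group on the same carbonyl carbon would test this.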